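Ring variation at the aryl terminus of the series

The source may report more compounds than this note shows. Statements on the series, on what has been measured and on what is new or still open speak of the compounds shown alone.

Measured so far:
Compound 1 `COC(=O)N1CCCCC1c1ccc(CNc2nccc(C)c2NC(=O)CC#N)cc1` — in an assay on isolated protein for binding affinity to B1 bradykinin receptor (Homo sapiens) (on this read-out higher numbers stand for weaker inhibition and lower numbers for stronger inhibition), compound 1 gives > 5000 nM, which is a limit of the assay rather than a number.
Compound 2 `COC(=O)C1=C(c2ccc(CNc3nccc(C)c3NC(=O)CC#N)cc2)CCC1` — in this assay compound 2 gives 126 nM.
Compound 3 `COC(=O)C1CCCN1c1ccc(CNc2nccc(C)c2NC(=O)CC#N)cc1` — in this assay compound 3 gives > 5000 nM, again a limit and not a number.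

Compound 1 therefore stands only at a limit, as does compound 3; the limit of > 5000 nM in this assay, at which 2 of the 3 values shown sit, is the common point. For the measured compounds named here, the one readable step is an at least 39-fold lower number from compound 1 to compound 2 (1.59 log units; beyond the scatter), and in the other direction an at least 39-fold higher number from compound 2 to compound 3 (1.59 log units; beyond the scatter), while a step that the two limits leave unreadable from compound 1 to compound 3 cannot be read at all.

Compound 4 `COC(=O)c1cccn1-c1ccc(CNc2nccc(C)c2NC(=O)CC#N)cc1` carries the change (2-(methoxycarbonyl)-1H-pyrrol-1-yl in place of 1-(methoxycarbonyl)piperidin-2-yl on an aromatic carbon). Going by the values given here, its entering group shares the five-membered ring with the group of compound 2 and the ring-nitrogen attachment with the group of compound 3, and no measured step covers exactly this combination. The expected step is an at least 1.6-fold lower number from compound 1 to compound 4 (0.22 log units; that floor lies within the scatter), with a real chance that only a limit is reported. Compound 4 is estimated at 3000 nM, in the range 300 nM to 30000 nM.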

Compound 4, inhibition constant: 250 nM
Beside the measured number, compound 4's estimate is 12-fold (1.08 log units) above it, and the stated range ends above it.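

Attachment through the ring nitrogen does not by itself hold a compound at the limit at this aromatic carbon: 2-(methoxycarbonyl)-1H-pyrrol-1-yl in place of 2-(methoxycarbonyl)pyrrolidin-1-yl gives an at least 20-fold lower number from compound 3 to compound 4 (1.30 log units; beyond the scatter). The same group gives an at least 20-fold lower number from compound 1 to compound 4 (1.30 log units; beyond the scatter), while against the 2-(methoxycarbonyl)cyclopent-1-en-1-yl group it gives a 2.0-fold higher number from compound 2 to compound 4 (0.30 log units; within the scatter), so these two groups cannot be told apart in this assay. The two large steps are floors and not sizes: the limit of > 5000 nM in this assay, at which 2 of the 4 values shown sit.

The compounds shown leave open whether the methoxycarbonyl group itself is needed, which a carboxylic acid or a primary amide on the same ring would test. They also leave open what an unsubstituted 1H-pyrrol-1-yl group would give on the shared core.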